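The source may hold more compounds than are shown below. What is called first, only, known or untested is meant among the compounds shown, and "the series" means these compounds.

Two compounds share one core and differ only in the last aromatic ring of the urea. Compound 1 `O=C(Nc1cccc(-n2cc(-c3ccncc3)c(-c3cc(O)cc(Cl)c3)n2)c1)Nc1ccc(Cl)c(C(F)(F)F)c1` carries a chloro group and a trifluoromethyl group on that ring, and in a functional assay on SF-539 cells (Homo sapiens) for inhibition, read by sulforhodamine B assay, with a stated time of 48 h, tested at 0.01 uM (on this read-out lower numbers stand for a stronger effect and higher numbers for a weaker effect at the one concentration tested), compound 1 gives 104%. Compound 2 `COc1cc(Cl)cc(-c2nn(-c3cccc(NC(=O)Nc4cc(C(F)(F)F)cc(C(F)(F)F)c4)c3)cc2-c2ccncc2)c1` carries two trifluoromethyl groups there, and in this assay compound 2 gives 100%. The two numbers lie within the usual scatter of each other, so compound 2 cannot be told apart from compound 1 on this evidence, and both sit at the level where the cells grow as if nothing had been added.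

Compound 3 `COc1cc(Cl)cc(-c2nn(-c3cccc(NC(=O)Nc4cccc(C(F)(F)F)c4)c3)cc2-c2ccncc2)c1` is still to be measured in this assay. Compared with compound 2 it differs in one place: hydrogen in place of trifluoromethyl on an aromatic carbon. Going by the values given here, no measured pair shows what such a change does here, so the expectation rests only on the two numbers given. Because compound 2 gives 100%, the step from compound 2 to compound 3 is expected to be none beyond the scatter, no change at the digits printed from compound 2 to compound 3 (within the scatter). Compound 3 is therefore estimated at 100%, with a range from 88% to 112%.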

Compound 3, a percentage reported as activity, at one concentration (the size of the read-out at that concentration, not a potency): 100%
The estimate for compound 3 equals the measured number at the digits printed, within the range that was stated.
By their numbers in this assay, from the lowest: compounds 2, 3 and 1 (each within the scatter of the next).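

In this assay, going by these compounds alone, leaving hydrogen where one trifluoromethyl group stood gives no change at the digits printed from compound 2 to compound 3 (within the scatter), the first reading of a single change at this position, since the earlier compounds offered no such pair. At the one concentration tested, then, this aromatic carbon accepts either trifluoromethyl or hydrogen without any difference the read-out can detect, although compound 2 and compound 3 both stay at the level of untreated growth, so a loss of effect could not have shown here in any case. Nothing measured here explains this result, and the flat step is all that can be reported.

From the compounds shown here alone, it remains open whether a different group at this carbon, such as an amine, a carboxylic acid or a longer chain, would shift the number in either direction, and whether taking away the remaining trifluoromethyl group would do so. Going by these compounds, it is also open whether the two compounds would still match at a concentration where the cells respond, as a single reading at the no-effect level cannot settle that.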